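The source may report more compounds than this note shows. Statements on the series, on what has been measured and on what is new or still open speak of the compounds shown alone.

The measured compounds:
compound 1, `Cc1nc(NCc2cccc(C(=O)O)c2)c2cn[nH]c2n1`: in an assay for inhibition of Indoleamine 2,3-dioxygenase 1 (Homo sapiens), read by spectrophotometry, with a stated time of 180 min, tested at 1 uM (on this read-out lower numbers stand for a weaker effect and higher numbers for a stronger effect at the one concentration tested), compound 1 gives 3%
compound 2, `Cc1nc(NCc2ccc(C(=O)O)cc2)c2cn[nH]c2n1`: in this assay compound 2 gives 3%
compound 3, `O=C(O)c1cccc(CNc2ncnc3[nH]ncc23)c1`: in this assay compound 3 gives 2%

All three read-outs sit close together, so none of the three can be set apart from the others.

Compound 2 is built from the same atoms as compound 1, joined differently; how the two cores differ is not broken down here. Compound 3 differs from compound 1 in one place only: hydrogen in place of methyl on an aromatic carbon. This change gave a number 1 percentage points lower from compound 1 to compound 3 (within the scatter), a step too small to count as a real difference.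

Compound 4, `O=C(O)c1ccc(CNc2ncnc3[nH]ncc23)cc1`, is not yet measured. It stands to compound 2 as compound 3 stands to compound 1: hydrogen in place of methyl on an aromatic carbon. The surroundings of the changed carbon are described in exactly the same words in both cases, so this is the same change made a second time.

Compound 2 gives 3%, and the earlier instance of this change gave a number 1 percentage points lower from compound 1 to compound 3 (within the scatter). On that basis the expected step is a number 1 percentage points lower from compound 2 to compound 4 (within the scatter). Compound 4 is therefore estimated to give 2% in this assay, with a likely range from -5% to 10%.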

Compound 4, a percentage reported as inhibition, at one concentration (the size of the read-out at that concentration, not a potency): 3%
The estimate for compound 4 lay 1 percentage points below the measured number, within the range that was stated.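

In this assay, putting hydrogen in place of methyl on the aromatic carbon gave no change at the digits printed from compound 2 to compound 4 (within the scatter). Set beside the first instance of this change, the second cannot be told apart from it, so in this small series the change carries from one core to the other without a detectable difference: the same change on two cores in this assay, a number 1 percentage points lower (within the scatter) from compound 1 to compound 3 and no change at the digits printed (within the scatter) from compound 2 to compound 4, 1 percentage points apart, within the scatter of two such steps This does not show that the methyl is unimportant in general, since all four compounds give small numbers at the one concentration tested, and two silent steps say nothing about how the same change would behave on a compound with a clearly stronger effect.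

The compounds shown leave open whether any other group on that carbon, such as an amine or a longer chain in place of the methyl, would move the read-out beyond the scatter. They also leave open what happens when the carboxylic acid is replaced by another group, such as an amide.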